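Chloro on the Aryl Ring, Moved from One Core to Another

A few compounds are considered here, and "the series" means these few. Any claim that something is new, unique, unknown or untested is made for them only; others in the source may bear on it.

Compound 1 `CCOC(=O)C1=C(C)N(c2ccccc2)C=CC1c1ccccc1` and compound 2 `CCOC(=O)C1=C(C)N(c2ccc(Cl)cc2)C=CC1c1ccccc1` share one core, while compound 3 `COC(=O)C1=C(C)N(c2ccccc2)C=C(C)C1c1ccccc1` is built on a different core, and compound 4 `COC(=O)C1=C(C)N(c2cccc(Cl)c2)C=C(C)C1c1ccccc1` is the chloro analogue of compound 3. In a functional assay, tested at 200 ug/mL (a higher number here means a weaker effect of the compound at the concentration tested, a lower number a stronger effect), compound 1 gives -34%. In this assay compound 2 gives -37.4%. The step between them, a number 3.4 percentage points lower from compound 1 to compound 2 (within the scatter), belongs to the change (chloro in place of hydrogen on an aromatic carbon). In this assay compound 3 gives -48%, the lowest of the three numbers and hence the strongest effect seen so far; its differences from compound 2 and from compound 1 both lie beyond the scatter. How the core of compound 3 differs from the core of compound 1 is not broken down here.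

The change from compound 3 to compound 4 is chloro in place of hydrogen on an aromatic carbon. It is the same kind of change as that from compound 1 to compound 2, not the same one: in compound 2 the chloro sits para to a large group, in compound 4 meta to a large group. Since the earlier step of a number 3.4 percentage points lower from compound 1 to compound 2 (within the scatter) stayed within the scatter, the step from compound 3 to compound 4 is also expected to be small, estimated as a number 2 percentage points lower from compound 3 to compound 4 (within the scatter). Compound 4 is therefore expected to give about -50% in this assay, most likely between -62% and -38%.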

Compound 4, a percentage reported as activity, at one concentration (the size of the read-out at that concentration, not a potency): -35.3%
For compound 4 the middle estimate is 14.7 percentage points below the measured one; the measured number lies above the stated range.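

In this assay the chloro change on the core of compound 3 came out as a number 12.7 percentage points higher from compound 3 to compound 4 (beyond the scatter) and so left compound 4 with a weaker effect at the concentration tested than compound 3, whereas the same kind of change on the core of compound 1 had stayed within the scatter. Set side by side, the two steps show that the size of this change was not carried over unaltered from one core to the other in this series: the same change on two cores in this assay, a number 3.4 percentage points lower (within the scatter) from compound 1 to compound 2 and a number 12.7 percentage points higher (beyond the scatter) from compound 3 to compound 4, 16.1 percentage points apart, beyond the scatter of two such steps. Within the data shown here, this does not show that the core alone sets the size of the step, for the chloro of compound 4 sits meta to a large group and that of compound 2 does not, so core and place change together, and each core offers only a single pair.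

Left open is whether the chloro would give a similar step if it stood in the same place on both cores, which would separate the part of the core from the part of the place. Also open, going by these compounds, is how a methoxy group, an amine or a carboxylic acid on that aryl ring would read in this assay on either core.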